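The source may hold more compounds than are shown below. What is called first, only, known or untested is meant among the compounds shown, and "the series" means these compounds.

Working notes on the series in a functional assay on SK-OV-3 cells (Homo sapiens) for antiproliferative activity, read by MTT assay, with a stated time of 24 h; a higher number here means a weaker inhibitor, a lower number a stronger inhibitor. Going by the values given here, compound 1 `COc1ccc(C(=O)/C=C/c2cccc([N+](=O)[O-])c2)c2c1C=CC(C)(C)O2` gives 9720 nM, the only true number so far. Compound 2 `COc1ccc(C(=O)/C=C/c2ccc(Cl)cc2)c2c1C=CC(C)(C)O2` reads > 10000 nM, which is a limit of the assay and not a number. Compound 3 `COc1ccc(C(=O)/C=C/c2ccccc2Cl)c2c1C=CC(C)(C)O2` reads > 10000 nM, likewise a limit and not a number. Compound 3 therefore has no exact position and stands at the limit of > 10000 nM in this assay, at which 2 of the 3 values shown sit.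

Compound 4 `COc1ccccc1/C=C/C(=O)c1ccc(OC)c2c1OC(C)(C)C=C2` differs from compound 3 in one place, with methoxy in place of chloro on an aromatic carbon, ortho to a large group: methoxy in place of chloro on an aromatic carbon.

The measured steps that bear on this change all alter the same aryl group. The first is an at least 1.0-fold higher number from compound 1 to compound 3 (0.01 log units; that floor lies within the scatter), and the second is an at least 1.0-fold higher number from compound 1 to compound 2 (0.01 log units; that floor lies within the scatter). Moving the chloro gives a step that the two limits leave unreadable from compound 2 to compound 3. Among the compounds with values here, no measured step replaces chloro with methoxy, so the effect of this exact change remains unknown.

Given an at least 1.0-fold higher number from compound 1 to compound 3 (0.01 log units; that floor lies within the scatter), no step beyond the scatter is expected in this assay, and no direction is favoured. The expected step is a step that the limit leaves unreadable from compound 3 to compound 4. A further limit rather than a number would not be surprising. Compound 4 is estimated at 11000 nM, with an expected range from 4000 nM to 30000 nM.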

Compound 4, half-maximal inhibitory concentration: > 10000 nM
Compound 4 gave a limit, no number (the forecaster's own chance of this, stated with the estimate: 60%); the middle value does not contradict the limit.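

In this assay compound 4 reads > 10000 nM, which is a limit and not a number. Going by these compounds alone, the only readable step is an at least 1.0-fold higher number from compound 1 to compound 4 (0.01 log units; that floor lies within the scatter), and the steps to compound 4 from compound 3 and from compound 2 cannot be read, so methoxy in place of chloro on an aromatic carbon, ortho to a large group, gives no measurable change. The new information is that a second group at this position, not only chloro, leaves the reading at the same limit, and 2-methoxyphenyl joins 2-chlorophenyl and 4-chlorophenyl there: the limit of > 10000 nM in this assay, at which 3 of the 4 values shown sit.

From the compounds shown here alone, how far compound 2, compound 3 and compound 4 lie past that limit remains open, and so does any real difference between methoxy and chloro at this position. Within the data shown here, also open is whether an amine or a carboxylic acid on this aryl ring would move the reading away from that of compound 1, 9720 nM, the only true number in the set.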